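The source may report more compounds than this note shows. Statements on the series, on what has been measured and on what is new or still open speak of the compounds shown alone.

Measured so far:
compound 1 `Cc1csc(-c2cncc(Cl)c2N2CCC3(CCNC3=O)CC2)c1`: 650 nM
compound 2 `Cc1ccc(-c2cncc(Cl)c2N2CCC3(CCNC3=O)CC2)s1`: 650 nM

In a functional assay on MV4-11 cells (Homo sapiens) for inhibition, read by resazurin assay, with a stated time of 72 h (a lower number here means a stronger inhibitor of growth, a higher number a weaker inhibitor of growth), compound 1 gives 650 nM and stands level with compound 2, the step of no change at the digits printed from compound 1 to compound 2 (within the scatter) lying within the scatter. Compound 3 `O=C1NCCC12CCN(c1c(Cl)cncc1-c1cn[nH]c1)CC2` differs from compound 1 by 1H-pyrazol-4-yl in place of 4-methylthiophen-2-yl on an aromatic carbon. Going by the values given here, the single measured step, 5-methylthiophen-2-yl in place of 4-methylthiophen-2-yl, does not touch an exchange of the whole ring, so no measured step bears on this change and the direction is open. For compound 3 the expected step is a 1.4-fold higher number from compound 1 to compound 3 (0.14 log units; within the scatter), giving an estimate of 900 nM with a wide range from 150 nM to 6000 nM.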

Compound 3, concentration for 50% growth inhibition: 8520 nM
Compound 3: middle estimate off by 9.5-fold (0.98 log units), on the low side, outside the stated range (above it).
By their numbers in this assay, from the lowest: compounds 1 and 2 (each within the scatter of the next); then compound 3.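

In this assay this position proves sensitive to exchange of the whole ring: 1H-pyrazol-4-yl costs much growth inhibition against 4-methylthiophen-2-yl (a 13-fold higher number from compound 1 to compound 3 (1.12 log units; beyond the scatter)) and equally against 5-methylthiophen-2-yl (a 13-fold higher number from compound 2 to compound 3 (1.12 log units; beyond the scatter)). Moving the methyl around the thiophene had shown no such sensitivity. No measurement at hand accounts for the loss.

Open, on these data alone, is whether the loss follows the ring nitrogens, the hydrogen on nitrogen or the absent methyl. An unsubstituted thiophen-2-yl or a 1-methylpyrazol-4-yl group would help separate these.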